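Removing the Propyl Chain from the Azepane Analogue

The compounds below may be only part of what the source reports. "The series", "measured", "known", "first", "only" and "open" are said of these compounds alone.

Compound 1 `CCCOP(=O)(O)OCCSC(=S)N1CCCCC1` gives > 100000 nM in a functional assay on MCF7 cells (Homo sapiens) for inhibition, read by MTT assay, with stated times of 18 h and 4 h (a higher number here means a weaker inhibitor, a lower number a stronger inhibitor), which is a limit of the assay and not a number. Compound 2 `CCCCCCOP(=O)(O)OCCSC(=S)N1CCCCCC1` gives 55000 nM in this assay. Compound 3 `CCCCCCOP(=O)(O)OCCSC(=S)N1CCCCC1` gives 62000 nM in this assay.

Compounds 2 and 3 share everything but the ring on the thiocarbonyl carbon, (azepan-1-yl in place of piperidin-1-yl on a thiocarbonyl carbon), and their values sit within the scatter of each other, a 1.1-fold higher number from compound 2 to compound 3 (0.05 log units; within the scatter). Compound 3 and compound 1 differ by hydrogen in place of propyl on a saturated chain carbon, three bonds along the chain from an oxygen on an unsaturated carbon, and that step weakened inhibition, an at least 1.6-fold higher number from compound 3 to compound 1 (0.20 log units; that floor lies within the scatter), with compound 1 sitting at the limit of > 100000 nM in this assay, at which 1 of the 3 values shown sits.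

Compound 4 `CCCOP(=O)(O)OCCSC(=S)N1CCCCCC1` is not yet measured. It differs from compound 2 by hydrogen in place of propyl on a saturated chain carbon, three bonds along the chain from an oxygen on an unsaturated carbon, the same change, at the same place, as from compound 3 to compound 1. The step from compound 2 to compound 4 is expected to be a 2.2-fold higher number from compound 2 to compound 4 (0.34 log units; beyond the scatter), resting on the step of an at least 1.6-fold higher number from compound 3 to compound 1 (0.20 log units; that floor lies within the scatter) seen for compound 1. Compound 4 is therefore estimated at 120000 nM, between 60000 nM and 250000 nM, quite possibly reported only as a limit.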

Compound 4, half-maximal inhibitory concentration: 74000 nM
Compound 4: the middle estimate sits 1.6-fold (0.21 log units) above what was measured, and the stated range covers the measured number.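

In this assay, cutting the hexyl chain back to propyl gives a 1.3-fold higher number from compound 2 to compound 4 (0.13 log units; within the scatter), so on this core the change cannot be told apart from repeat-measurement noise. Carried from one core to the other, the change shows no clear sign of a different size, but this does not prove that the size is the same: the same change on two cores in this assay, an at least 1.6-fold higher number (0.20 log units; that floor lies within the scatter) from compound 3 to compound 1 and a 1.3-fold higher number (0.13 log units; within the scatter) from compound 2 to compound 4; the limit leaves it open whether they differ. Compound 1 gives > 100000 nM, which is a limit of the assay and not a number.

The compounds shown leave open whether a chain longer than hexyl would shift the number beyond the scatter in this assay. They also leave open what a chain ending in an amine or a carboxylic acid would do.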